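Removing the isopropyl group from compound 2

The source may report more compounds than this note shows. Statements on the series, on what has been measured and on what is new or still open speak of the compounds shown alone.

Measured so far in a physicochemical assay for lipophilicity, read by HPLC, measured as chromatographic lipophilicity, at pH 7.4; a lower number here means a more polar compound, a higher number a more lipophilic compound:
- compound 1 `COc1cccc(NC(=O)c2nnn(CC3CCNCC3)c2N)c1`: 0.6
- compound 2 `COc1cccc(NC(=O)c2nnn(Cc3ccc(C(C)C)cc3)c2N)c1`: 3.4

Of the two measured compounds, compound 2 stands higher, at 3.4 in this assay. The next compound is compound 3 `COc1cccc(NC(=O)c2nnn(Cc3ccccc3)c2N)c1`, which has not yet been measured. Its difference from compound 2 is hydrogen in place of isopropyl on an aromatic carbon.

Among the compounds with values here, only one measured step bears on this change: a number 2.80 log units higher from compound 1 to compound 2 (beyond the scatter). That large step, beyond the scatter, exchanged piperidin-4-yl for the whole 4-isopropylphenyl group, so it bears on the present change only indirectly. Within the data shown here, no measured step isolates the isopropyl group. Compound 3 keeps the phenyl ring and loses only part of what that step introduced, so a smaller step in the downward direction, still beyond the scatter, is expected. The expected step is a number 1.00 log units lower from compound 2 to compound 3 (beyond the scatter). For compound 3 the estimated value is 2.4, with an expected range of 1.9 to 2.9.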

Compound 3, distribution coefficient: 2.6
Beside the measured number, compound 3's estimate is 0.20 log units below it; measured number inside the range.
By their numbers in this assay, from the lowest: compound 1; then compound 3; then compound 2.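

Isopropyl on an aromatic carbon of a six-membered aromatic ring of carbon only, para to a large group, can now be read on its own in this assay: with hydrogen in its place, the result is a modest step (a number 0.80 log units lower from compound 2 to compound 3 (beyond the scatter)). The exchange of piperidin-4-yl for phenyl on the saturated chain carbon is also separated from the isopropyl group, and it remains a large step (a number 2.00 log units higher from compound 1 to compound 3 (beyond the scatter)), so most of the earlier difference for 4-isopropylphenyl is already present with phenyl. Nothing available on these compounds gives a reason for either step.

Only isopropyl and hydrogen are shown at this aromatic carbon, so it remains open whether the number in this assay follows the size of the group there, which a methyl group or a tert-butyl group could test. Also open, on these data alone, is how a carboxylic acid or an amine at the same place would read, and whether the isopropyl step would carry over when the phenyl ring is attached through a longer chain.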